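This account rests on a few compounds, and the source may have more. Where it says the series, first, only, none or still open, it means among the compounds named here.

Compound 3 `O=C(O)c1ccccc1-c1ccc(CCc2ncc(-c3ccccc3)[nH]2)cc1` stands at the top of the three measured numbers in an in vitro functional assay on cells for agonist activity at Bombesin receptor subtype-3 (Mus musculus), read by luminescence and calcium flux (on this read-out lower numbers stand for an effect already at smaller amounts and higher numbers for an effect only at larger amounts of compound), with 872 nM. Compound 2 `CCCCc1cnc(CCc2ccc(-c3ccccc3C(=O)O)cc2)[nH]1` gives 93 nM, and compound 1 `O=C(O)c1ccccc1-c1ccc(CCc2ncc(Cc3ccccc3F)[nH]2)cc1` gives 9.5 nM; the gaps are a 9.4-fold higher number from compound 2 to compound 3 (0.97 log units; beyond the scatter) and a 92-fold higher number from compound 1 to compound 3 (1.96 log units; beyond the scatter), both beyond the scatter. The unmeasured compound 4 `CC(C)(C)c1cnc(CCc2ccc(-c3ccccc3C(=O)O)cc2)[nH]1` changes compound 3 in a single place: tert-butyl in place of phenyl on an aromatic carbon. Among the compounds with values here, only one measured step speaks directly to this change, the one in which a saturated butyl chain gave way to phenyl at the same position and the number rose by a 9.4-fold higher number from compound 2 to compound 3 (0.97 log units; beyond the scatter). Read in reverse, that step suggests that putting a saturated group back in place of phenyl should bring the number down again. Within the data shown here, compound 4 carries a branched rather than a straight saturated group, and no measured pair shows what branching alone does, so the return toward the number of compound 2 is expected to be only partial. The step from compound 3 to compound 4 is therefore estimated at a 4.4-fold lower number from compound 3 to compound 4 (0.64 log units; beyond the scatter), toward a lower number. Compound 4 is expected to give about 200 nM in this assay, with a likely range from 50 nM to 900 nM.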

Compound 4, half-maximal effective concentration: 2750 nM
Compound 4: middle estimate off by 14-fold (1.14 log units), on the low side; the measured number lies above the stated range.
By their numbers in this assay, from the lowest: compound 1; then compound 2; then compound 3; then compound 4.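

In this assay the change to tert-butyl gives a 3.2-fold higher number from compound 3 to compound 4 (0.50 log units; beyond the scatter) and so moves the number the opposite way from what the butyl and phenyl pair alone suggested, which shows that replacing phenyl with a saturated group does not by itself lower the number at this position. The shape of the saturated group matters here: replacing the straight butyl with the branched tert-butyl gives a 30-fold higher number from compound 2 to compound 4 (1.47 log units; beyond the scatter) and leaves compound 4 with the highest number of the four compounds. The distance from the best group shown, 2-fluorobenzyl, also grows to a 290-fold higher number from compound 1 to compound 4 (2.46 log units; beyond the scatter) and so spans a wide range of effect at this single ring carbon, but nothing available here explains why the branched group does so poorly.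

As far as these compounds go, it remains open whether a smaller branched group such as isopropyl would sit closer to butyl or to tert-butyl, and so whether branching itself or the size of the branch drives the rise. Also open, from the compounds shown here alone, is whether a plain benzyl group or a longer chain such as hexyl would match the low number of compound 1 at 9.5 nM.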